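The source may report more compounds than this note shows. Statements on the series, on what has been measured and on what is new or still open speak of the compounds shown alone.

Measured compounds in an ADME assay on HeLa cells (Homo sapiens) for cytotoxicity, read by MTT assay, with a stated time of 24 h; on this read-out lower numbers stand for stronger inhibition and higher numbers for weaker inhibition:
- compound 1 `CCOC(=O)N1CCN(C(=S)SC(=S)N(C)C)CC1`: 530000 nM
- compound 2 `CN(C)C(=S)SC(=S)N1CCN(c2cccc(Cl)c2)CC1`: a limit only, > 5000000 nM
- compound 3 `CN(C)C(=S)SC(=S)N1CCN(C(=O)c2ccco2)CC1`: 2380000 nM

Compound 3 stands at the highest of the two numbers given, with compound 1 nearest below it: a 4.5-fold higher number from compound 1 to compound 3 (0.65 log units; beyond the scatter). For compound 2 this assay reports only a limit, > 5000000 nM; one of the three values sits at the limit of > 5000000 nM in this assay, at which 1 of the 3 values shown sits. The step of an at least 2.1-fold lower number from compound 2 to compound 3 (0.32 log units; beyond the scatter) is therefore known only as a bound.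

Compound 4 `CSC(=S)N1CCN(C(=S)SC(=S)N(C)C)CC1` differs from compound 3 by a group of 4 heavy atoms (2 carbon, 2 sulfur; no ring) in place of a group of 7 heavy atoms (5 carbon, 2 oxygen; one five-membered aromatic ring with 1 hetero atom), on an amine nitrogen in a ring. Within the data shown here, no measured step exchanges the (furan-2-yl)carbonyl for a group of this kind; the step of a 4.5-fold higher number from compound 1 to compound 3 (0.65 log units; beyond the scatter) shows that a change on this carbonyl carbon moved the number by a modest amount, and an at least 9.4-fold higher number from compound 1 to compound 2 (0.97 log units; beyond the scatter) that the 3-chlorophenyl on the ring nitrogen carried the number to the limit. The small entering group resembles the ethoxycarbonyl of compound 1 more than the 3-chlorophenyl of compound 2, so a modest step toward lower numbers is expected, a 3.4-fold lower number from compound 3 to compound 4 (0.53 log units; beyond the scatter). Compound 4 is estimated at 700000 nM, between 200000 nM and 2500000 nM.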

Compound 4, half-maximal inhibitory concentration: > 5000000 nM
Compound 4 gave a limit, no number (the forecaster's own chance of this, stated with the estimate: 10%); middle value at least 7.1-fold (0.85 log units) from the limit.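

With the group of 4 heavy atoms (2 carbon, 2 sulfur; no ring) on the amine nitrogen in the ring, this assay shows an at least 2.1-fold higher number from compound 3 to compound 4 (0.32 log units; beyond the scatter), and the same group in place of the ethoxycarbonyl shows an at least 9.4-fold higher number from compound 1 to compound 4 (0.97 log units; beyond the scatter). A small group with no ring therefore does not bring the number toward that of compound 1, so neither a small size nor the absence of a ring is enough at this position. Compound 4 gives only a limit, and it joins compound 2 there: the limit of > 5000000 nM in this assay, at which 2 of the 4 values shown sit.

From the compounds shown here alone, the step between these two limits cannot be read, so any order of compound 2 and compound 4 remains unknown. Also open, going by these compounds, is whether the lower number of compound 1 persists with a longer chain on the oxygen of the ethoxycarbonyl, or with an amine on that carbonyl carbon in place of the ethoxy.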